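One Ether Arm Changed on a Shared Core

A few compounds are considered here, and "the series" means these few. Any claim that something is new, unique, unknown or untested is made for them only; others in the source may bear on it.

Of the compounds shown here, three built on one shared core have been tested in a functional assay on HL-60 cells (Homo sapiens) for inhibition, read by MTT assay, with a stated time of 48 h, tested at 10 uM; on this read-out lower numbers stand for less inhibition of growth and higher numbers for more inhibition of growth at the one concentration tested. Compound 1 `COc1ccc(COc2cc(O)c3c(=O)cc(C)oc3c2[C@H]2CCN(C)C[C@H]2O)cc1` gives 23%, compound 2 `Cc1cc(=O)c2c(O)cc(OCc3ccc(Br)cc3)c([C@H]3CCN(C)C[C@H]3O)c2o1` gives 27%, and compound 3 `Cc1cc(=O)c2c(O)cc(OCc3ccccc3Br)c([C@H]3CCN(C)C[C@H]3O)c2o1` gives 3%. Compound 2 holds the highest of the three numbers, yet its lead over compound 1 lies within the scatter, so those two cannot be ranked; only compound 3 sits clearly lower.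

The unmeasured compound 4 `Cc1cc(=O)c2c(O)cc(OC/C=C/c3ccccc3)c([C@H]3CCN(C)C[C@H]3O)c2o1` differs from compound 2 in one place: 2-phenylethenyl in place of 4-bromophenyl on a saturated chain carbon bound to an oxygen on an aromatic ring Put another way, the (4-bromobenzyl)oxy arm becomes a (3-phenylprop-2-en-1-yl)oxy arm.

Going by the values given here, no measured step makes exactly this change, but two kinds of step touch the same arm. The step of a number 4 percentage points higher from compound 1 to compound 2 (within the scatter) shows that exchanging one group for another on the ring of that arm left the number essentially unchanged. The steps of a number 24 percentage points lower from compound 2 to compound 3 (beyond the scatter) and a number 20 percentage points lower from compound 1 to compound 3 (beyond the scatter) show that moving the bromine to a different spot on that ring lowered the number by a modest amount. Compound 4 keeps an aromatic ring on the arm and adds one double bond outside aromatic rings, a change of a different kind, and the data give no direction for it. The step of a number 5 percentage points lower from compound 2 to compound 4 (within the scatter) is therefore expected to lie within the scatter or to be modest at most. For compound 4 the expected value is 22%, with a range from 5% to 40%.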

Compound 4, percent growth inhibition at one concentration: 21%
Compound 4: the middle estimate sits 1 percentage points above what was measured; measured number inside the range.
By their numbers in this assay, from the lowest: compound 3; then compounds 4, 1 and 2 (each within the scatter of the next).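

The step of a number 6 percentage points lower from compound 2 to compound 4 (within the scatter) and the step of a number 2 percentage points lower from compound 1 to compound 4 (within the scatter) in this assay show that an arm ending in 2-phenylethenyl, with its 1 double bond outside aromatic rings, cannot be told apart from the arms ending in 4-bromophenyl or 4-methoxyphenyl. The earlier compounds shown here only compared substituted phenyl groups at this place, on a saturated chain carbon bound to an oxygen on an aromatic ring, whereas compound 4 shows that neither a bromine nor a methoxy on the ring is needed to reach this level. Going by these compounds alone, the step of a number 18 percentage points higher from compound 3 to compound 4 (beyond the scatter) leaves compound 3 as the one compound of the four that goes against this picture, so its low number goes with the 2-bromophenyl arm and not with every change at this place.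

From the compounds shown here alone, what happens when the ring on this arm gives way to a plain propyl chain, or when the arm carries an amine or a carboxylic acid, stays open. Nothing at hand explains why the numbers fall as they do.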